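Methoxy to hydroxy on the solubility scale

The compounds below may be only part of what the source reports. "The series", "measured", "known", "first", "only" and "open" are said of these compounds alone.

compound 1 `Cc1ccc2nc(C(=O)c3ccc(F)c(O)c3)ccc2c1` gives 25000 nM
compound 2 `Cc1cc(-c2ccc3ccc(C(=O)c4ccc(F)c(O)c4)nc3c2)ccc1O` gives 13000 nM
compound 3 `COc1cc(C(=O)c2ccc3ccccc3n2)ccc1F` gives 100000 nM

In a physicochemical assay for solubility, in phosphate buffer, with a stated time of 24 h, at pH 7.4, tested at 200 uM (on this read-out higher numbers stand for higher solubility and lower numbers for lower solubility), compound 3 gives 100000 nM as the highest of the three numbers, and its gaps to compound 1 and compound 2 both lie beyond the scatter. Compound 4 `O=C(c1ccc(F)c(O)c1)c1ccc2ccccc2n1` has not yet been measured. It differs from compound 3 by hydrogen in place of methyl on an oxygen on an aromatic ring with hydrogen in place of methyl on an oxygen on an aromatic ring, which is methoxy to hydroxy. Among the measured compounds shown here, no measured pair shows this change alone. Compound 1 at 25000 nM and compound 2 at 13000 nM both carry the hydroxy and both stand lower than compound 3, but each also has further groups on the core, so they offer only a loose guide. In this assay the estimated step is a 2.2-fold lower number from compound 3 to compound 4 (0.35 log units; beyond the scatter) and it is expected to run towards a lower number, at the edge of the scatter or a little beyond it. For compound 4 the estimate is 45000 nM with an expected range from 18000 nM to 110000 nM in this measurement.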

Compound 4, solubility: > 200000 nM
Compound 4 gave a limit, no number; the forecaster's own chance of this, stated with the estimate: 5%; middle value at least 4.4-fold (0.64 log units) from the limit.
By their numbers in this assay, from the lowest: compounds 2 and 1 (each within the scatter of the next); then compound 3. At a limit, above all of these: compound 4.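

In this assay compound 4 gave a limit and not a number: the limit of > 200000 nM in this assay, at which 1 of the 4 values shown sits. Among the compounds shown here, with methoxy to hydroxy read on its own for the first time, the change shows an at least 2.0-fold higher number from compound 3 to compound 4 (0.30 log units; that floor lies within the scatter), so the step on this oxygen on an aromatic ring does not run towards a lower number, although its floor lies within the scatter. Hydrogen in place of methyl on an aromatic carbon gives an at least 8.0-fold higher number from compound 1 to compound 4 (0.90 log units; beyond the scatter), and hydrogen in place of 4-hydroxy-3-methylphenyl on an aromatic carbon gives an at least 15-fold higher number from compound 2 to compound 4 (1.18 log units; beyond the scatter), so the floors beyond the scatter belong to the changes on aromatic carbon.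

Going by these compounds, all three steps are floors, so their full sizes remain open. Also open, on these data alone, is how a longer chain or an amine on this oxygen would stand in this assay.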